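The source may hold more compounds than are shown below. What is called first, only, known or untested is meant among the compounds shown, and "the series" means these compounds.

Measured so far in an assay on HEK293 cells for positive allosteric modulation of metabotropic glutamate receptor 5 (Homo sapiens), read by FLIPR, with a stated time of 1 h; a higher number here means that more compound is needed for the effect, a lower number that less compound is needed:
compound 1 `O=C(C1CCC1)N1CCc2nc(C#Cc3ccccc3)sc2C1`: > 10000 nM
compound 2 `O=C(C1CCCCC1)N1CCc2nc(C#Cc3ccccc3)sc2C1`: 167 nM

For the measured compounds named here, compound 2 holds the only number in this assay. For compound 1 the assay reports a limit, not a number: the limit of > 10000 nM in this assay, at which 1 of the 2 values shown sits. Going by the values given here, the single measured step is an at least 59-fold lower number from compound 1 to compound 2 (1.77 log units; beyond the scatter), a change of ring size on the carbonyl carbon.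

Compound 3 `CC1CCC(C(=O)N2CCc3nc(C#Cc4ccccc4)sc3C2)CC1` differs from compound 2 by methyl in place of hydrogen on a saturated ring carbon, cyclohexyl to 4-methylcyclohexyl. Among the compounds with values here, no measured step covers substitution on that ring; the one step known concerns ring size only. Compound 3 is therefore expected to stay near compound 2, with the step of a 1.3-fold lower number from compound 2 to compound 3 (0.11 log units; within the scatter) within the scatter. Compound 3 is estimated at 130 nM, range 40 nM to 450 nM.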

Compound 3, half-maximal effective concentration: 190 nM
The estimate for compound 3 lay 1.5-fold (0.16 log units) below the measured number; the range from low to high includes it.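

In this assay the saturated ring carbon of the cyclohexyl group takes a methyl without a change beyond the scatter, the step being a 1.1-fold higher number from compound 2 to compound 3 (0.06 log units; within the scatter) in the 4-methylcyclohexyl amide. The large separation from the cyclobutyl amide also persists with this substituent, at an at least 52-fold lower number from compound 1 to compound 3 (1.72 log units; beyond the scatter) as the second step. That second step is bounded on one side only, as compound 1 has a limit and not a number: the limit of > 10000 nM in this assay, at which 1 of the 3 values shown sits.

On these data alone, whether a hydroxyl, an amine or a longer chain such as ethyl at that ring carbon behaves like methyl remains open. So does the outcome with a cyclopentyl group on the carbonyl carbon.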